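The source may hold more compounds than are shown below. What is called first, only, known or untested is meant among the compounds shown, and "the series" means these compounds.

Compound 3 `CC(C)(C)N(NC(=O)c1ccccc1I)C(=O)c1ccccc1Cl` gives 1290 nM in an assay on cells for agonist activity at ecdysone receptor (Bombyx mori), read by a luciferase reporter, with a stated time of 24 h (on this read-out higher numbers stand for an effect only at larger amounts of compound and lower numbers for an effect already at smaller amounts), which is the highest of the three numbers gathered so far. Compound 1 `CC(C)(C)N(NC(=O)c1ccccc1)C(=O)c1ccccc1F` gives 309 nM in this assay, and compound 2 `COc1ccccc1C(=O)N(NC(=O)c1ccccc1)C(C)(C)C` gives 525 nM; the gap from either of these to compound 3 lies beyond the scatter. Among the compounds with values here, the only measured single step, a 1.7-fold higher number from compound 1 to compound 2 (0.23 log units; within the scatter), stays within the scatter and concerns a different part of the molecule.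

Compound 4 `Cc1cccc(C(=O)NN(C(=O)c2ccccc2Cl)C(C)(C)C)c1` differs from compound 3 in one place: 3-methylphenyl in place of 2-iodophenyl on a carbonyl carbon. Within the data shown here, no measured pair shows this exchange, so the expectation rests on where compound 3 stands relative to compound 1 and compound 2, both of which carry an unsubstituted phenyl on that carbonyl carbon and give lower numbers. Removing the 2-iodophenyl is therefore expected to move compound 4 toward those numbers, an estimated 3.2-fold lower number from compound 3 to compound 4 (0.51 log units; beyond the scatter). Compound 4 is expected to give about 400 nM, within a range from 150 nM to 1200 nM.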

Compound 4, half-maximal effective concentration: 603 nM
Beside the measured number, compound 4's estimate is 1.5-fold (0.18 log units) below it; the measured number falls inside the stated range.
By their numbers in this assay, from the lowest: compounds 1, 2 and 4 (each within the scatter of the next); then compound 3.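

Within the data shown here, at this position, on a carbonyl carbon whose other neighbour is an amide-type nitrogen, the exchange of 2-iodophenyl for 3-methylphenyl gives a 2.1-fold lower number from compound 3 to compound 4 (0.33 log units; beyond the scatter) in this assay, the first measured step here and a modest one that lies beyond the scatter. The number therefore responds to this exchange even though the leaving and entering groups have the same count of heavy atoms, one carbon-only aromatic ring each, and no hydrogen-bond donors or acceptors, so the difference lies in the iodine, the methyl, or the places given in their names. Nothing available accounts for the size or the direction of this step.

On these data alone, whether the iodine or the place of the group matters remains open, and 3-iodophenyl or 2-methylphenyl at this carbonyl carbon would bear on that question. As far as these compounds go, how groups of a different kind would fare here, such as 3-aminophenyl or 3-carboxyphenyl, also remains open.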